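This account rests on a few compounds, and the source may have more. Where it says the series, first, only, none or still open, it means among the compounds named here.

Working notes on the series. Three compounds carry a value in a functional assay on COLO 205 cells (Homo sapiens) for inhibition, read by sulforhodamine B assay, with a stated time of 48 h, tested at 50 uM; on this read-out higher numbers stand for more inhibition of growth at the one concentration tested and lower numbers for less inhibition of growth. Compound 1 `COc1cc(/C=C/C(=O)/C=C/c2ccccc2)ccc1OCc1cn(CCCOc2cc(=O)oc3ccccc23)nn1` gives 43% in this assay. Compound 2 `COc1ccccc1/C=C/C(=O)/C=C/c1ccc(OCc2cn(CCOc3cc(=O)oc4ccccc34)nn2)c(OC)c1` gives 67% in this assay. Compound 3 `COc1cc(/C=C/C(=O)/C=C/c2cccc3ccccc23)ccc1OCc1cn(CCCOc2cc(=O)oc3ccccc23)nn1` gives 64% in this assay. Compound 2 thus stands beyond the scatter above compound 1, while its gap to compound 3 lies within the scatter, so no order between compound 2 and compound 3 is claimed. Among the measured compounds shown here, the one single-point step measured is a number 21 percentage points higher from compound 1 to compound 3 (beyond the scatter), a change at the same place as the one considered here.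

Compound 4 `COc1cc(/C=C/C(=O)/C=C/c2cccs2)ccc1OCc1cn(CCOc2cc(=O)oc3ccccc23)nn1` is not yet measured. Its difference from compound 2 is thiophen-2-yl in place of 2-methoxyphenyl on a double-bonded chain carbon bound to a double-bonded chain carbon. For the measured compounds named here, no measured step exchanges an aromatic ring of this kind at that place, so the step from compound 1 to compound 3 bears on it only as a sign that this position tolerates change of the aromatic ring. The expected step is therefore small, a number 12 percentage points lower from compound 2 to compound 4 (beyond the scatter), with wide uncertainty. Compound 4 is estimated at 55%, in the range 35% to 75%.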

Compound 4, percent growth inhibition at one concentration: 66%
Compound 4: middle estimate off by 11 percentage points, on the low side; the measured number falls inside the stated range.
By their numbers in this assay, from the lowest: compound 1; then compounds 3, 4 and 2 (each within the scatter of the next).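

In this assay, the exchange of 2-methoxyphenyl for thiophen-2-yl gives a number 1 percentage points lower from compound 2 to compound 4 (within the scatter) at this place, on a double-bonded chain carbon bound to a double-bonded chain carbon. The number therefore holds within the scatter when a six-membered aromatic ring of carbon only with 8 heavy atoms gives way to a five-membered aromatic ring with 1 hetero atom and 5 heavy atoms, whereas the earlier step at this place, a number 21 percentage points higher from compound 1 to compound 3 (beyond the scatter), had shown only a change beyond the scatter. No measurement shown gives a reason for this outcome.

The compounds shown leave open whether a non-aromatic group at this place, such as cyclohexyl or a chain ending in an amine, would hold the number. Also open, as far as these compounds go, is whether a carboxylic acid on the thiophen-2-yl ring would do so.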